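The source may report more compounds than this note shows. Statements on the series, on what has been measured and on what is new or still open speak of the compounds shown alone.

Working notes on the series. Compound 1 `CC(C)n1c(/C=C2/C(=O)Nc3ccc(Br)cc32)nc2ccccc21` in a functional assay on PC-3 cells (Homo sapiens) for cytotoxicity, read by MTT assay, with a stated time of 48 h (a lower number here means a stronger inhibitor, a higher number a weaker inhibitor), gives 10700 nM. Compound 2 `CC(C)n1c(/C=C2/C(=O)Nc3ccc(F)cc32)nc2ccccc21` in this assay gives 20800 nM. The change between them is fluoro in place of bromo on an aromatic carbon and the step is a 1.9-fold higher number from compound 1 to compound 2 (0.29 log units; within the scatter). Within the data shown here, compound 3 `Cn1c(/C=C2/C(=O)Nc3ccc(Br)cc32)nc2ccccc21` in this assay gives only a limit, > 50000 nM, which is a limit of the measurement and not a number; it is the one value among the three that sits at the limit of > 50000 nM in this assay, at which 1 of the 3 values shown sits. The core of compound 3 differs from that of compound 1 by methyl in place of isopropyl on an aromatic nitrogen, and the step is an at least 4.6-fold higher number from compound 1 to compound 3 (0.66 log units; beyond the scatter). Compound 4 `Cn1c(/C=C2/C(=O)Nc3ccc(F)cc32)nc2ccccc21` is not yet measured in this assay. It differs from compound 3 by fluoro in place of bromo on an aromatic carbon, the same change as from compound 1 to compound 2, since the two place descriptions agree word for word. From compound 3 to compound 4 the expected step is a step that the limit leaves unreadable from compound 3 to compound 4, resting on a 1.9-fold higher number from compound 1 to compound 2 (0.29 log units; within the scatter), which stayed within the scatter, and on the limit that compound 3 already reaches. Compound 4 is therefore expected near 100000 nM, from 40000 nM to 300000 nM, most likely reported again only as a limit.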

Compound 4, half-maximal inhibitory concentration: 34300 nM
Beside the measured number, compound 4's estimate is 2.9-fold (0.46 log units) above it; measured number outside the range, below it.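

Fluoro in place of bromo gives an at least 1.4-fold lower number from compound 3 to compound 4 (0.16 log units; that floor lies within the scatter) in this assay, and this does not match the step on the other core: the same change on two cores in this assay, a 1.9-fold higher number (0.29 log units; within the scatter) from compound 1 to compound 2 and an at least 1.4-fold lower number (0.16 log units; that floor lies within the scatter) from compound 3 to compound 4, at least 2.8-fold (0.45 log units) apart, beyond the scatter of two such steps. Methyl in place of isopropyl gives a 1.6-fold higher number from compound 2 to compound 4 (0.22 log units; within the scatter), which likewise differs from the earlier step: the same change on two cores in this assay, an at least 4.6-fold higher number (0.66 log units; beyond the scatter) from compound 1 to compound 3 and a 1.6-fold higher number (0.22 log units; within the scatter) from compound 2 to compound 4, at least 2.8-fold (0.45 log units) apart, beyond the scatter of two such steps. Compound 3 gives only a limit, > 50000 nM, and both gaps are floors resting on it; they show that neither change carries as a fixed step between these cores, but not how large the true gap is or what lies behind it.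

The compounds shown leave open whether the same gaps appear with an ethyl group or a longer chain on the aromatic nitrogen, or with chloro or an amine on the aromatic carbon in place of bromo. They also leave open whether the mismatch extends beyond this single set of four compounds.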